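The source may report more compounds than this note shows. Statements on the series, on what has been measured and on what is new or still open speak of the compounds shown alone.

The series is read in a functional assay on HCT-116 cells (Homo sapiens) for inhibition, read by CCK-8 assay, with a stated time of 72 h, tested at 8 uM; on this read-out higher numbers stand for more inhibition of growth at the one concentration tested and lower numbers for less inhibition of growth. Compound 1, `Nc1ccccc1NC(=O)c1ccc(CSc2nccc(C(F)(F)F)n2)cc1`, gives 93.1%. Compound 3, `Nc1ccccc1NC(=O)c1ccc(CSc2ccc(C(F)(F)F)cn2)cc1`, gives 25.8%. Compound 2, `Nc1ccccc1NC(=O)/C=C/c1ccc(CSc2ccc(F)cc2)cc1`, gives 20.2%, the smallest of the three numbers; its distance to compound 3 lies within the usual scatter, so the two cannot be told apart, whereas compound 1 stands beyond the scatter above it. Going by the values given here, no two of the measured compounds differ in a single place, so no step between them can be measured directly.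

Compound 4, `Nc1ccccc1NC(=O)/C=C/c1ccc(CSc2cccc(F)c2)cc1`, has not yet been measured. It is related to compound 2 by one change, (3-fluorophenyl in place of 4-fluorophenyl on a sulfur), the two sharing the same atoms joined differently. Nothing among the three measured compounds shows what such a change does on this read-out. The author therefore expects the step from compound 2 to compound 4 to be small, most likely none beyond the scatter, and writes it as a number 4.8 percentage points higher from compound 2 to compound 4 (within the scatter). For compound 4 the estimated value in this assay is 25%, with a range from 10% to 45%, the actual measurement being left to follow.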

Compound 4, percent growth inhibition at one concentration: 3.22%
Estimate against measurement, compound 4: 21.8 percentage points above, outside the stated range (below it).
By their numbers in this assay, from the lowest: compound 4; then compounds 2 and 3 (each within the scatter of the next); then compound 1.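

Going by these compounds alone, the step of a number 17 percentage points lower from compound 2 to compound 4 (beyond the scatter) is the first single-place comparison, and it concerns the group on the sulfur. In this assay, within the data shown here, replacing 4-fluorophenyl with 3-fluorophenyl changes the result beyond the scatter, even though the two groups have the same atoms and the same counts under the structural comparison, so the read-out distinguishes these two arrangements of fluorophenyl on the sulfur, with compound 4 at 3.22% in a series where the earlier compounds could show nothing of the kind. Nothing shown explains why this exchange lowers the growth inhibition.

The compounds shown leave open what other groups on this sulfur would do, such as an unsubstituted phenyl, a chlorophenyl, a methoxyphenyl or a phenyl carrying an amine, and so it cannot be said whether the step reflects something particular to fluorine or applies more widely. They also leave open whether the same exchange would have a comparable effect on the core of compound 1 or compound 3, as neither has a partner differing from it in one place.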